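A few compounds are considered here, and "the series" means these few. Any claim that something is new, unique, unknown or untested is made for them only; others in the source may bear on it.

Measured compounds:
- compound 1, `COc1ccc(OC)c([C@@H]2[C@H](OC)C(=O)N2C/C(C#N)=C/c2ccccc2)c1`, 23400 nM in a functional assay on MDA-MB-231 cells (Homo sapiens) for antiproliferative activity, read by MTT assay, with a stated time of 48 h; a higher number here means a weaker inhibitor, a lower number a stronger inhibitor
- compound 2, `COC(=O)/C(=C/c1ccccc1)CN1C(=O)[C@@H](OC)[C@H]1c1cccc(C(F)(F)F)c1`, 18200 nM in this assay

Of the compounds shown here, two have been measured so far. In this assay compound 1 gives 23400 nM, and in this assay compound 2 gives 18200 nM. The gap between these two numbers lies within the scatter of the method, so compound 2 stands alongside compound 1 and neither can be said to inhibit the cells more strongly than the other; both sit in the weak range.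

Compound 3, `COC(=O)/C(=C/c1ccccc1)CN1C(=O)[C@@H](OC)[C@H]1c1ccc(OC)cc1`, has not yet been measured. It differs from compound 2 in one place: 4-methoxyphenyl in place of 3-(trifluoromethyl)phenyl on a saturated ring carbon. The two aryl groups exchanged here share one six-membered aromatic ring of carbon only and differ in the group carried on it.

Among the compounds with values here, no step between measured compounds is available to guide the expectation, and the two known numbers give no sign that this part of the molecule moves the read-out much. The step from compound 2 to compound 3 is therefore expected to be small, a 1.2-fold higher number from compound 2 to compound 3 (0.08 log units; within the scatter), and not beyond the scatter in either direction. For compound 3 the estimated value in this assay is 22000 nM, expected to fall between 8000 nM and 60000 nM.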

Compound 3, half-maximal inhibitory concentration: 14000 nM
The estimate for compound 3 lay 1.6-fold (0.20 log units) above the measured number; measured number inside the range.
By their numbers in this assay, from the lowest: compounds 3, 2 and 1 (each within the scatter of the next).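

In this assay, within the data shown here, the exchange of 3-(trifluoromethyl)phenyl for 4-methoxyphenyl on the saturated ring carbon of the four-membered ring gives a 1.3-fold lower number from compound 2 to compound 3 (0.11 log units; within the scatter), and this is the first direct reading of any change at this position. Among these compounds, the two aryl groups differ in the substituent and in where it sits on the aromatic ring, and the entering group carries a hydrogen-bond acceptor that the leaving group lacks, yet this combined exchange stays within the scatter, and the single step cannot separate the two differences. No measurement is available to account for this outcome.

The compounds shown leave open whether this position responds to anything other than a substituted phenyl group, such as a pyridine ring or a phenyl group bearing an amine or a carboxylic acid. Compounds 2 and 3 also share the methyl ester and the methoxy group on the four-membered ring, so they leave open what would follow if a carboxylic acid replaced that ester or an amine replaced that methoxy group.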